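Series notes: aromatic nitrogen methyl versus hydrogen, cytotoxicity

A few compounds are considered here, and "the series" means these few. Any claim that something is new, unique, unknown or untested is made for them only; others in the source may bear on it.

Measured so far:
- compound 1, `CCN(CC)CC(=O)Nc1ccc(-c2nc3cc(C(F)(F)F)ccc3[nH]2)cc1`: 8000 nM
- compound 2, `CC(=O)Nc1ccc(-c2nc3cc(C(F)(F)F)ccc3[nH]2)cc1`: 19000 nM
- compound 3, `Cn1c(-c2ccc(NC(=O)CN3CCCCC3)cc2)nc2cc(C(F)(F)F)ccc21`: 9000 nM

In an ADME assay on MT4 cells (Homo sapiens) for cytotoxicity, read by MTT assay, with a stated time of 96 h (a lower number here means that less compound is tolerated, a higher number that more compound is tolerated), compound 3 stands second highest of the three numbers; its value sits within the scatter of that of compound 1, while against compound 2 the gap is beyond the scatter, compound 2 giving the higher number.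

Compound 4, `O=C(CN1CCCCC1)Nc1ccc(-c2nc3cc(C(F)(F)F)ccc3[nH]2)cc1`, differs from compound 3 at one place: hydrogen in place of methyl on an aromatic nitrogen. Within the data shown here, the only measured step in the set, a 2.4-fold higher number from compound 1 to compound 2 (0.38 log units; beyond the scatter), concerns the saturated chain carbon bound to the carbonyl carbon and gives a modest shift; it does not touch the aromatic nitrogen and so does not bear directly on the change from compound 3 to compound 4. Among the measured compounds shown here, no measured pair reports the effect of a methyl against a hydrogen at that aromatic nitrogen. The expected step for compound 4 is therefore a 1.1-fold lower number from compound 3 to compound 4 (0.02 log units; within the scatter), which is no step beyond the scatter.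

For compound 4 in this assay the estimated value is 8500 nM, with a range from 4000 nM to 18000 nM.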

Compound 4, half-maximal cytotoxic concentration: 6000 nM
Beside the measured number, compound 4's estimate is 1.4-fold (0.15 log units) above it; the measured number falls inside the stated range.
By their numbers in this assay, from the lowest: compounds 4, 1 and 3 (each within the scatter of the next); then compound 2.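

In this assay the aromatic nitrogen gets its first reading: hydrogen in place of methyl gives a 1.5-fold lower number from compound 3 to compound 4 (0.18 log units; within the scatter) and so leaves this pair without a change beyond the scatter. Among these compounds, on the saturated chain carbon bound to the carbonyl carbon, piperidin-1-yl in place of diethylamino gives a 1.3-fold lower number from compound 1 to compound 4 (0.12 log units; within the scatter) while piperidin-1-yl in place of hydrogen gives a 3.2-fold lower number from compound 2 to compound 4 (0.50 log units; beyond the scatter) and thus marks the chain carbon, not the aromatic nitrogen, as the place of the one new step beyond the scatter. No measured evidence bearing on the cause of these steps is available.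

The exchange of methyl for hydrogen at the aromatic nitrogen rests on a single pair, with piperidin-1-yl on the chain. Open, on these data alone, are a longer chain on that aromatic nitrogen and a primary amine or a carboxylic acid on the saturated chain carbon.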